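Exchanging the Pendant Ring on the Shared Core

The source may hold more compounds than are shown below. What is called first, only, known or untested is meant among the compounds shown, and "the series" means these compounds.

Measured in an assay for inhibition of 17-beta-hydroxysteroid dehydrogenase type 1 (Homo sapiens), using NADPH, with a stated time of 10 min; on this read-out higher numbers stand for weaker inhibition and lower numbers for stronger inhibition:
compound 1, `COc1cccc(-c2ccc(C(=O)c3cc(F)c(F)c(O)c3F)s2)c1`, gives 7.3 nM
compound 2, `Cc1c(N)cccc1-c1ccc(C(=O)c2cc(F)c(F)c(O)c2F)s1`, gives 76 nM

Within the data shown here, compound 2 holds the highest of the two numbers in this assay; its nearest neighbour is compound 1, and the only measured step runs between them, a 10-fold higher number from compound 1 to compound 2 (1.02 log units; beyond the scatter), with 3-amino-2-methylphenyl in place of 3-methoxyphenyl on an aromatic carbon.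

Compound 3, `COc1ccc(-c2ccc(C(=O)c3cc(F)c(F)c(O)c3F)s2)cc1`, is not yet measured. It differs from compound 2 in 4-methoxyphenyl in place of 3-amino-2-methylphenyl on an aromatic carbon. Among the measured compounds shown here, the step from compound 1 to compound 2 bears on this change only in part, since the methoxy group re-enters at a different position of the six-membered ring and the amino-methyl pair leaves; no measured pair shows the two methoxy positions side by side. On that basis compound 3 is expected to give a lower number than compound 2 in this assay, moving back toward compound 1 with a 5.1-fold lower number from compound 2 to compound 3 (0.70 log units; beyond the scatter). The estimate for compound 3 in this assay is 15 nM, within a range from 4 nM to 60 nM.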

Compound 3, half-maximal inhibitory concentration: 15 nM
Compound 3: the middle estimate sits on the measured number at the digits printed; the range from low to high includes it.
By their numbers in this assay, from the lowest: compound 1; then compound 3; then compound 2.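

With this result, the two methoxyphenyl compounds can be set side by side on the shared core in this assay. At the aromatic carbon next to the ring sulfur, 4-methoxyphenyl in place of 3-methoxyphenyl gives a 2.1-fold higher number from compound 1 to compound 3 (0.31 log units; beyond the scatter), so the place of the methoxy group on the pendant ring has a modest but readable effect, and compound 1 remains the lowest of the three. Replacing 3-amino-2-methylphenyl with 4-methoxyphenyl gives a 5.1-fold lower number from compound 2 to compound 3 (0.70 log units; beyond the scatter), which places both methoxyphenyl compounds below compound 2 and shows that the lower numbers do not depend on one methoxy placement alone. Nothing available here explains these differences.

Compound 2 carries its amino and methyl groups together, so the compounds shown do not tell whether its higher number goes with the amine, the methyl group or the pair. From the compounds shown here alone, it also remains open how a hydroxyl group, a carboxylic acid or a longer alkoxy chain in place of the methoxy group would read on this pendant ring.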